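Hydrogen for fluoro on compound 2

The compounds below may be only part of what the source reports. "The series", "measured", "known", "first", "only" and "open" are said of these compounds alone.

In a physicochemical assay for solubility, read by nephelometry, measured as kinetic solubility, at pH 6.5, tested at 10 mg/mL (a lower number here means a less soluble compound, a higher number a more soluble compound), compound 1 (`Cc1c(F)cccc1C(=O)Nc1cc(Cl)ccn1`) gives 12.5 ug/mL and compound 2 (`Cc1c(C(=O)Nc2ccccn2)ccc(F)c1F`) gives 25 ug/mL as its number, the two lying within the scatter of each other, so compound 2 stands level with compound 1. Compound 3 (`Cc1c(F)cccc1C(=O)Nc1ccccn1`) carries hydrogen in place of fluoro on an aromatic carbon of compound 2 (hydrogen in place of fluoro on an aromatic carbon). Within the data shown here, no measured pair shows this change and the two values give no direction, so no step beyond the scatter is expected in this assay for it. The estimated step runs no change at the digits printed from compound 2 to compound 3 (within the scatter) and stays within the scatter. Compound 3 is estimated at 25 ug/mL with an expected range from 10 ug/mL to 60 ug/mL around it.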

Compound 3, solubility: 25 ug/mL
Compound 3: the middle estimate sits on the measured number at the digits printed, within the range that was stated.
By their numbers in this assay, from the lowest: compounds 1, 2 and 3 (each within the scatter of the next).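

In this assay, among these compounds, hydrogen in place of fluoro on the aromatic carbon ortho to a fluoro group and meta to a methyl group gives no change at the digits printed from compound 2 to compound 3 (within the scatter), the first reading of this change at this position. Hydrogen in place of chloro on an aromatic carbon gives a 2.0-fold higher number from compound 1 to compound 3 (0.30 log units; within the scatter), so at these two places neither halogen stands apart from hydrogen beyond the scatter. No measurement here bears on a cause for either step.

Open, going by these compounds, is whether an amine or a carboxylic acid on the same aromatic carbon would move the number beyond the scatter in this assay. On these data alone, a longer chain in place of the methyl group also remains open.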